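Dechlorination step in a carbamate series, liver microsome stability

The source may report more compounds than this note shows. Statements on the series, on what has been measured and on what is new or still open speak of the compounds shown alone.

Measured so far:
- compound 1, `COC(=O)Nc1cc(-c2cnc(OC[C@@](C)(N)CC(C)C)cc2C)ccn1`: in an ADME assay on microsomes from liver (Homo sapiens) for metabolic stability, read by LC-MS, using NADPH, with a stated time of 10 min, tested at 0.5 uM (a higher number here means that more of the compound is left, a lower number that less of the compound is left), compound 1 gives 98%
- compound 2, `COC(=O)Nc1cc(-c2cnc(OC[C@@](C)(N)CC(C)C)c(Cl)c2)ccn1`: in this assay compound 2 gives 90%

Compound 2 stands lowest of the two numbers in this assay; its nearest neighbour is compound 1, whose value is higher by an amount that lies within the scatter, so no order between the two can be claimed. Both values sit near the top of the read-out.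

Compound 3, `COC(=O)Nc1cc(-c2ccc(OC[C@@](C)(N)CC(C)C)nc2)ccn1`, is the next member. It differs from compound 2 as follows: hydrogen in place of chloro on an aromatic carbon. Among the measured compounds shown here, no step between measured compounds is available for this change, so the expectation rests only on compound 2 and compound 1 both being high in this assay. The estimated step of a number 2 percentage points higher from compound 2 to compound 3 (within the scatter) is expected to be small, none beyond the scatter. Compound 3 is expected to give 92%, with a range from 80% to 99%.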

Compound 3, percent of the compound remaining: 100%
The estimate for compound 3 lay 8 percentage points below the measured number; the measured number lies above the stated range.
By their numbers in this assay, from the lowest: compounds 2, 1 and 3 (each within the scatter of the next).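

In this assay, hydrogen in place of chloro on an aromatic carbon, ortho to a (2-amino-2,4-dimethylpentyl)oxy group, gives a number 10 percentage points higher from compound 2 to compound 3 (within the scatter), and hydrogen in place of methyl gives a number 2 percentage points higher from compound 1 to compound 3 (within the scatter), so neither substituent is shown to matter for this read-out. Compound 3 gives 100%, the top of the read-out, which leaves no room to resolve any further rise from this parent. No measurement bearing on the reason for these numbers is available.

As far as these compounds go, whether a methoxy or trifluoromethyl group at this place would give a step beyond the scatter remains open. Also open, from the compounds shown here alone, is how the number would respond to a change elsewhere, such as an ethyl carbamate in place of the methyl carbamate or a shorter chain in place of the (2-amino-2,4-dimethylpentyl)oxy group.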